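A few compounds are considered here, and "the series" means these few. Any claim that something is new, unique, unknown or untested is made for them only; others in the source may bear on it.

In a functional assay on the whole organism (strain Swiss albino) for inhibition, with Mus musculus as the target, in the writhing test, with a stated time of 30 min, at a dose of 100 mg/kg by the intraperitoneal route (on this read-out higher numbers stand for more inhibition at the one dose given (going by the name of the read-out) and lower numbers for less inhibition), compound 2 `O=C(CSc1ccccc1C(=O)O)Nc1ccc(Cl)cc1` gives 49.7%. For the measured compounds named here, only one other number stands beside it: compound 1 `O=C(CSc1ccccc1C(=O)O)Nc1ccccc1`, which gives 54.8% in this assay, and the step of a number 5.1 percentage points lower from compound 1 to compound 2 (within the scatter) lies within the scatter, so the two numbers are not told apart.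

Compound 3 `O=C(CSc1ccccc1C(=O)O)Nc1ccc(Br)cc1` is reached from compound 2 by one change: bromo in place of chloro on an aromatic carbon. Going by the values given here, the one measured step touches the same position, where chloro replaced hydrogen, and it moved the number by a number 5.1 percentage points lower from compound 1 to compound 2 (within the scatter), a shift within the scatter. Among the compounds with values here, no measured pair shows bromo against chloro, so the expectation leans on that single step alone and on the smallness of the change.

Compound 3 is therefore expected to give about 48% in this assay, the step of a number 1.7 percentage points lower from compound 2 to compound 3 (within the scatter) being one that should not exceed the scatter, with a likely range from 36% to 60%.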

Compound 3, a percentage reported as inhibition, in the whole organism at one dose (the size of the read-out at that dose, not a potency): 9.04%
Beside the measured number, compound 3's estimate is 39 percentage points above it, and the stated range ends above it.
By their numbers in this assay, from the lowest: compound 3; then compounds 2 and 1 (each within the scatter of the next).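

In this assay, the aromatic carbon para to a large group proves sensitive to which halogen it carries, although the earlier pair gave no sign of this. The change from 4-chlorophenyl to 4-bromophenyl brings a number 40.7 percentage points lower from compound 2 to compound 3 (beyond the scatter), whereas chloro in place of hydrogen had stayed within the scatter. Bromo in place of hydrogen brings a number 45.8 percentage points lower from compound 1 to compound 3 (beyond the scatter), so among the three groups shown here, only bromo separates from the others, and a single small atom swap can matter far more at this position than the first step suggested.

Going by these compounds, whether fluoro, iodo, methyl or methoxy at this same place would stay with hydrogen and chloro or fall with bromo remains open. Nothing available on these compounds offers an explanation for the drop.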